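Methyl Removal on a Four-Membered Ring: Predicting Compound 4

A few compounds are considered here, and "the series" means these few. Any claim that something is new, unique, unknown or untested is made for them only; others in the source may bear on it.

Compound 1 `C[C@]1(O)C[C@](c2cccc(C(F)(F)F)c2)([C@H](O)c2ccccn2)C1` and compound 2 `O[C@H](c1ccccn1)[C@]1(c2cccc(C(F)(F)F)c2)C[C@H](O)C1` share a core and differ in one place: hydrogen in place of methyl on a saturated ring carbon. In an assay on HEK293 cells for antagonist activity at transient receptor potential cation channel subfamily V member 3 (Homo sapiens), read by FLIPR and calcium flux (on this read-out higher numbers stand for weaker inhibition and lower numbers for stronger inhibition), compound 1 gives 1550 nM, while compound 2 gives 90 nM, a step of a 17-fold lower number from compound 1 to compound 2 (1.24 log units; beyond the scatter). Compound 3 `C[C@]1(O)C[C@@](c2cc(C(F)(F)F)ccn2)([C@H](O)c2ccccn2)C1` carries a different core; how it differs from compound 1 is not broken down here. In this assay compound 3 gives 730 nM. Compound 4 `O[C@H](c1ccccn1)[C@]1(c2cc(C(F)(F)F)ccn2)C[C@@H](O)C1` relates to compound 3 by the same change, (hydrogen in place of methyl on a saturated ring carbon), at a place described in the same words. Because a 17-fold lower number from compound 1 to compound 2 (1.24 log units; beyond the scatter) was large and the place is identical, compound 4 is expected to show a step of a 12-fold lower number from compound 3 to compound 4 (1.09 log units; beyond the scatter) in this assay, somewhat smaller than the earlier one to allow for scatter. Compound 4 is therefore estimated at 60 nM, within 20 nM to 200 nM.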

Compound 4, antagonist equilibrium constant: 320 nM
Beside the measured number, compound 4's estimate is 5.3-fold (0.73 log units) below it, outside the stated range (above it).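

In this assay the change again goes the same way, with a 2.3-fold lower number from compound 3 to compound 4 (0.36 log units; beyond the scatter), so its direction holds on both cores. Its size does not carry over from one core to the other: the same change on two cores in this assay, a 17-fold lower number (1.24 log units; beyond the scatter) from compound 1 to compound 2 and a 2.3-fold lower number (0.36 log units; beyond the scatter) from compound 3 to compound 4, 7.5-fold (0.88 log units) apart, beyond the scatter of two such steps These two pairs do not show what in the cores accounts for that gap, and they set no rule for how large the step would be on a further core.

The compounds shown leave open how the saturated ring carbon would respond to a group other than methyl or hydrogen, such as an ethyl group or an amine. They also leave open whether the step would keep its direction with a nitrile in place of the trifluoromethyl group.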